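A few compounds are considered here, and "the series" means these few. Any claim that something is new, unique, unknown or untested is made for them only; others in the source may bear on it.

Three compounds of the series have a number in a physicochemical assay for solubility, read by nephelometry, in phosphate buffer, measured as kinetic solubility, at pH 6.5; on this read-out higher numbers stand for higher solubility and lower numbers for lower solubility. Compound 1 `CCOC(=O)C1=C(C)N/C(=C/c2cc(C)n(-c3ccc(CN(C)C)cc3)c2C)C1=O` gives 12.5 ug/mL in this assay. Compound 2 `CCOC(=O)C1=C(C)N/C(=C/c2cc(C)n(-c3ccc(SC(F)(F)F)cc3)c2C)C1=O` gives 1 ug/mL. Compound 3 `CCOC(=O)C1=C(C)N/C(=C/c2cc(C)n(-c3ccc(SC)cc3)c2C)C1=O` gives 1.6 ug/mL, the second highest of the three: it sits close to compound 2 and well apart from compound 1. The step of a 7.8-fold lower number from compound 1 to compound 3 (0.89 log units; beyond the scatter) bears most directly on the next compound; the step of a 13-fold lower number from compound 1 to compound 2 (1.10 log units; beyond the scatter) points the same way, and the step of a 1.6-fold higher number from compound 2 to compound 3 (0.20 log units; within the scatter) is small.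

Compound 4 `CCOC(=O)C1=C(C)N/C(=C/c2cc(C)n(-c3ccc(CN4CCCCC4)cc3)c2C)C1=O` differs from compound 3 in one place: (piperidin-1-yl)methyl in place of methylsulfanyl on an aromatic carbon. This change runs the kind of exchange seen between compound 1 and compound 3 in reverse, an aminomethyl group again entering where a sulfur-linked group leaves, so the step measured from compound 1 to compound 3 is the main guide. For compound 4 an upward step in this assay is expected, a 5.0-fold higher number from compound 3 to compound 4 (0.70 log units; beyond the scatter). The estimate for compound 4 in this assay is 8 ug/mL, within a range of 3 ug/mL to 25 ug/mL.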

Compound 4, solubility: 12.5 ug/mL
For compound 4 the middle estimate is 1.6-fold (0.19 log units) below the measured one, and the stated range covers the measured number.
By their numbers in this assay, from the lowest: compounds 2 and 3 (each within the scatter of the next); then compounds 1 and 4 (each within the scatter of the next).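

In this assay, on this aromatic carbon, para to a large group, (piperidin-1-yl)methyl in place of methylsulfanyl gives a 7.8-fold higher number from compound 3 to compound 4 (0.89 log units; beyond the scatter) and in place of (trifluoromethyl)sulfanyl gives a 13-fold higher number from compound 2 to compound 4 (1.10 log units; beyond the scatter) as a second amine-bearing comparison, so the gap to the sulfur-linked compounds no longer rests on compound 1 alone. Piperidin-1-yl in place of dimethylamino on the saturated chain carbon gives no change at the digits printed from compound 1 to compound 4 (within the scatter) and so separates neither amine from the other on this read-out. Nothing measured here accounts for the gap between the amine-bearing and sulfur-linked compounds.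

Open, as far as these compounds go, is whether the ring nitrogen is needed at this position: a methoxymethyl group would address that. Open too, from the compounds shown here alone, is whether a (morpholin-4-yl)methyl or (piperazin-1-yl)methyl group would stay level with compound 1 and compound 4.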